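Ethyl in Place of Methylsulfonyl on the Shared Core

This account rests on a few compounds, and the source may have more. Where it says the series, first, only, none or still open, it means among the compounds named here.

This account follows three agonists built on a shared core and a fourth not yet tested. In an assay on CHO cells with Alpha-2C adrenergic receptor (Homo sapiens) as the target (a higher number here means a larger maximal response, a lower number a smaller maximal response), compound 1 `CCOc1ccccc1OC(C)C1=NCCN1` gives 0.45, compound 2 `CC(Oc1ccccc1Br)C1=NCCN1` gives 0.87, and compound 3 `CC(Oc1ccccc1S(C)(=O)=O)C1=NCCN1` gives 0.6. Compound 3 therefore stands second highest of the three numbers in this assay, with compound 1 nearest, a number a number 0.15 higher from compound 1 to compound 3 (beyond the scatter), and compound 2 furthest, a number a number 0.27 lower from compound 2 to compound 3 (beyond the scatter). The step to compound 4 `CCc1ccccc1OC(C)C1=NCCN1` is ethyl in place of methylsulfonyl on an aromatic carbon, on the aromatic carbon ortho to a group of 8 heavy atoms. Among the measured compounds shown here, no measured step brings in ethyl itself; the steps that bear on it are the replacement of ethoxy by methylsulfonyl, a number 0.15 higher from compound 1 to compound 3 (beyond the scatter), and of bromo by methylsulfonyl, a number 0.27 lower from compound 2 to compound 3 (beyond the scatter), which bracket methylsulfonyl between a lower and a higher neighbour. Since ethyl is a two-carbon group without oxygen or sulfur, like neither neighbour exactly, a step of a number 0.10 higher from compound 3 to compound 4 (within the scatter) in this assay is expected, close to the scatter. Compound 4 is estimated at 0.7, between 0.45 and 0.9.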

Compound 4, intrinsic activity: the largest response reached, as a fraction of the reference agonist's: 0.6
Beside the measured number, compound 4's estimate is 0.10 above it, and the stated range covers the measured number.
By their numbers in this assay, from the lowest: compound 1; then compounds 3 and 4 (each within the scatter of the next); then compound 2.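

In this assay ethyl in place of methylsulfonyl gives no change at the digits printed from compound 3 to compound 4 (within the scatter) on this aromatic carbon, so a group of 2 carbon atoms with 0 hydrogen-bond acceptors stands level with one of 4 heavy atoms with 2 hydrogen-bond acceptors. Ethyl in place of bromo gives a number 0.27 lower from compound 2 to compound 4 (beyond the scatter) and ethyl in place of ethoxy gives a number 0.15 higher from compound 1 to compound 4 (beyond the scatter) here, the same gaps that methylsulfonyl holds to those two compounds. Nothing at hand accounts for these numbers. The compounds shown leave open whether a longer chain such as propyl, an amine or a carboxylic acid on this carbon would stay level with compound 3 and compound 4 or come closer to compound 2 or compound 1. They also leave open whether ethyl and methylsulfonyl would still match on another carbon of the ring.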